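From benzyl to 1-phenylethyl on the shared core

A few compounds are considered here, and "the series" means these few. Any claim that something is new, unique, unknown or untested is made for them only; others in the source may bear on it.

Three amides on a shared core have been measured in a functional assay on U-937 cells (Homo sapiens) for antiproliferative activity, read by MTT assay, with a stated time of 24 h (a lower number here means a stronger inhibitor, a higher number a weaker inhibitor), where compound 1 (`CCCCc1oc2ccccc2c1C(=O)c1ccc(OCC(=O)N2CCCCC2)cc1`) gives 37100 nM while compound 2 (`CCCCc1oc2ccccc2c1C(=O)c1ccc(OCC(=O)Nc2ccccc2)cc1`) gives 25900 nM and compound 3 (`CCCCc1oc2ccccc2c1C(=O)c1ccc(OCC(=O)NCc2ccccc2)cc1`) gives 16300 nM on the same scale. Among the compounds with values here, compound 3 stands clear of compound 1 only, with a 2.3-fold lower number from compound 1 to compound 3 (0.36 log units; beyond the scatter) as the one modest step in the set. Against compound 2 it cannot be separated, since a 1.6-fold lower number from compound 2 to compound 3 (0.20 log units; within the scatter) is the whole of that gap.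

Compound 4 (`CCCCc1oc2ccccc2c1C(=O)c1ccc(OCC(=O)N[C@@H](C)c2ccccc2)cc1`) keeps everything in compound 3 except one change (methyl in place of hydrogen on a saturated chain carbon bound to an amide-type nitrogen and an aromatic carbon) which turns benzyl to 1-phenylethyl. Within the data shown here, no measured pair tests a methyl on this carbon, so the evidence is indirect. The three amide groups compared so far differ far more in shape than this change does, yet a 1.4-fold lower number from compound 1 to compound 2 (0.16 log units; within the scatter) stays small. The largest step among them is the modest one from compound 1 to compound 3. A step of similar or smaller size is therefore expected, in neither direction with confidence and probably none beyond the scatter. The expected change is a 1.1-fold lower number from compound 3 to compound 4 (0.04 log units; within the scatter) on this estimate. Compound 4 is estimated at 15000 nM in this assay with an expected range from 8000 nM to 30000 nM around that figure.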

Compound 4, half-maximal inhibitory concentration: 33800 nM
Beside the measured number, compound 4's estimate is 2.3-fold (0.35 log units) below it; measured number outside the range, above it.
By their numbers in this assay, from the lowest: compounds 3, 2, 4 and 1 (each within the scatter of the next, the first and the last beyond it).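

In this assay, within the data shown here, the saturated chain carbon bound to an amide-type nitrogen and an aromatic carbon turns out to respond to a single added methyl: a 2.1-fold higher number from compound 3 to compound 4 (0.32 log units; beyond the scatter) is a modest step beyond the scatter, of the same grade as the one step that had separated the earlier amides. With this methyl the separation held by the benzyl amide is lost, since a 1.3-fold higher number from compound 2 to compound 4 (0.12 log units; within the scatter) and a 1.1-fold lower number from compound 1 to compound 4 (0.04 log units; within the scatter) both lie within the scatter, and (1-phenylethyl)amino cannot be told apart from either anilino or piperidin-1-yl on the carbonyl carbon. Nothing among the measurements shown offers an explanation for this step.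

The compounds shown leave open whether the step belongs to methyl alone or would continue with ethyl or hydroxymethyl on the same carbon, and whether two methyl groups there would behave differently. They also leave open how the mirror-image form of compound 4 would read on this scale, so a single configuration at this carbon is all that can be spoken for.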